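This account rests on a few compounds, and the source may have more. Where it says the series, first, only, none or still open, it means among the compounds named here.

Measured in an assay on isolated protein for inhibition of Hematopoietic prostaglandin D synthase (Homo sapiens), read by ELISA; on this read-out higher numbers stand for weaker inhibition and lower numbers for stronger inhibition:
Compound 2 `c1ccc(-c2ncc(-c3cnc(-c4ccccc4)[nH]3)cn2)cc1` gives 59 nM.
Compound 1 `c1ccc(-c2ncc(-c3cnc(-c4ccccn4)nc3)[nH]2)cc1` gives 5060 nM.

Among these two numbers compound 2 stands lowest, its only neighbour being compound 1, separated by an 86-fold lower number from compound 1 to compound 2 (1.93 log units; beyond the scatter). Compound 3 `c1ccc(-c2ncc(-c3cnc(-c4cccnc4)[nH]3)cn2)cc1` differs from compound 2 by pyridin-3-yl in place of phenyl on an aromatic carbon. Among the compounds with values here, the one measured step also exchanges a pyridinyl for phenyl, though with pyridin-2-yl and in a different arrangement of the core, so it bears on this change only loosely; run backwards it points toward a weaker result. For compound 3 in this assay a moderate rise is expected, a 3.4-fold higher number from compound 2 to compound 3 (0.53 log units; beyond the scatter), to an estimated 200 nM (range 50 nM to 1000 nM).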

Compound 3, half-maximal inhibitory concentration: 12.5 nM
Compound 3: middle estimate off by 16-fold (1.20 log units), on the high side; the measured number lies below the stated range.
By their numbers in this assay, from the lowest: compound 3; then compound 2; then compound 1.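

In this assay, putting pyridin-3-yl in place of phenyl at this position gives a 4.7-fold lower number from compound 2 to compound 3 (0.67 log units; beyond the scatter), so here a ring nitrogen goes with stronger inhibition, not weaker. The earlier step, which involved pyridin-2-yl and a different arrangement of the core, pointed the other way, so a pyridinyl group does not weaken inhibition in every setting. No supporting data explain this gain. Still open, from the compounds shown here alone, is whether pyridin-2-yl or pyridin-4-yl at this same position would match pyridin-3-yl. Also open, going by these compounds, is how a pyridin-3-yl ring carrying an amine or a methoxy group would compare.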